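Methoxy in Place of Ethyl on a Shared Core

The compounds below may be only part of what the source reports. "The series", "measured", "known", "first", "only" and "open" are said of these compounds alone.

Two measured compounds share one core and differ only in the groups on the carbon-only ring. Compound 1 `CCc1cc(C)cc2nc(N3CCN(C)CC3)oc12` carries an ethyl group, and in a functional assay on ileum (strain Hartley) for agonist activity at 5-hydroxytryptamine receptor 3A (Cavia porcellus) (on this read-out higher numbers stand for higher potency (the scale is a negative logarithm) and lower numbers for lower potency), compound 1 gives 6.46. Compound 2 `Cc1cc(Cl)cc2nc(N3CCN(C)CC3)oc12` carries a chlorine in the place of the methyl group's neighbour on that ring, and in this assay compound 2 gives 6.7. The gap between these two numbers lies within the usual scatter, so compound 1 and compound 2 cannot be told apart on this read-out.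

Compound 3 `COc1cc(C)cc2nc(N3CCN(C)CC3)oc12` is not yet measured. It differs from compound 1 in one place: methoxy in place of ethyl on an aromatic carbon. Among the measured compounds shown here, no measured pair shows what this exchange does, so the step is expected to be small, in no clear direction, and probably not beyond the scatter. For compound 3 the estimated value in this assay is 6.5, between 5.9 and 7.1, a step from compound 1 to compound 3 of a number 0.04 log units higher from compound 1 to compound 3 (within the scatter).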

Compound 3, negative logarithm of the half-maximal effective concentration: 6.13
Beside the measured number, compound 3's estimate is 0.37 log units above it, within the range that was stated.
By their numbers in this assay, from the lowest: compound 3; then compounds 1 and 2 (each within the scatter of the next).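

Among the compounds shown here, this pair gives the first reading of a change at this position. On the shared core, methoxy in place of ethyl on an aromatic carbon, ortho to a fused ring, gives a number 0.33 log units lower from compound 1 to compound 3 (beyond the scatter) in this assay, so the read-out does respond to which group sits here, although the step is modest. The data offer no explanation for the direction or size of this step.

This single exchange cannot show whether the drop belongs to the oxygen of methoxy or to the loss of ethyl, nor whether the same exchange would give a similar step on another substitution pattern of the core. On these data alone, how an amine, a hydroxyl group or a longer chain such as propyl would behave in this place also remains open.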